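Cytotoxicity notes on the step to compound 4

The source may hold more compounds than are shown below. What is called first, only, known or untested is meant among the compounds shown, and "the series" means these compounds.

Going by the values given here, in an ADME assay on HEK293 cells (Homo sapiens) for cytotoxicity, read by MTT assay, with a stated time of 24 h (on this read-out higher numbers stand for weaker inhibition and lower numbers for stronger inhibition), compound 2 `COC(=O)c1scc(-c2ccc(NC(=O)c3cccc(I)c3)cc2)c1OC` gives 42700 nM as the only number so far. For compound 1 `COC(=O)c1scc(-c2ccc(NC(=O)c3ccccn3)cc2)c1OC` the entry reads "not determined" (no result reported) and no number exists. For compound 3 `COC(=O)c1scc(-c2ccc(NC(=O)c3ccc(C#N)nc3)cc2)c1OC` the entry likewise reads "not determined" (no result reported) and so compound 3 has no place on the scale, with compound 1 the one other entry lacking a number. Compound 4 `COC(=O)c1scc(-c2ccc(NC(=O)c3ccc(C(F)(F)F)cc3)cc2)c1OC` awaits measurement in this assay and has no number yet. The structural change 4-(trifluoromethyl)phenyl in place of 6-cyanopyridin-3-yl on a carbonyl carbon puts 4-(trifluoromethyl)phenyl in place of 6-cyanopyridin-3-yl on a carbonyl carbon. Among the compounds with values here, the series offers no measured step, so the size of this change cannot be read from the data. Compound 4 is expected to sit close to compound 2 at 42700 nM with no step beyond the usual scatter in either direction, an expectation resting on a single number. The estimate for compound 4 is 40000 nM within an expected range from 15000 nM to 100000 nM for this measurement.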

Compound 4, half-maximal inhibitory concentration: 48300 nM
Beside the measured number, compound 4's estimate is 1.2-fold (0.08 log units) below it; the range from low to high includes it.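

In this assay the series now has its first readable step, a 1.1-fold higher number from compound 2 to compound 4 (0.05 log units; within the scatter) with 4-(trifluoromethyl)phenyl in place of 3-iodophenyl on a carbonyl carbon. At this place, on a carbonyl carbon whose other neighbour is the amide-type nitrogen, the read-out does not separate these two groups. This is a single pair and does not make a pattern.

Going by these compounds, the steps involving compound 1 and compound 3 cannot be read, so whether their nitrogen-containing rings at this place give a different reading stays open. Also open, on these data alone, is how an aliphatic amine or a carboxylic acid on this carbonyl carbon would read. No measured evidence bears on why the two groups read alike.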